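One Stereocentre Changed at the Assay Limit

The compounds below may be only part of what the source reports. "The series", "measured", "known", "first", "only" and "open" are said of these compounds alone.

In a functional assay on Vero cells (Chlorocebus sabaeus) for inhibition (on this read-out lower numbers stand for stronger inhibition and higher numbers for weaker inhibition), compound 1 (`OC[C@H]1O[C@H](n2cnc3c(O)ncnc32)CS1`) gives > 100000 nM, which is a limit of the assay and not a number.

Compound 2 (`Nc1ncnc2c1ncn2[C@H]1CS[C@@H](CO)O1`) gives > 100000 nM in this assay, and this too is only a limit. Its true value is therefore unknown, and no exact comparison with compound 1 can be made.

Compound 3 (`Nc1ncnc2c1ncn2[C@@H]1CS[C@@H](CO)O1`) remains to be tested. It differs from compound 2 only in spatial arrangement: the two compounds have the same atoms and bonds and differ only in configuration as drawn: 1 of 2 stereo elements differ; a stereocentre at a saturated ring carbon is drawn R in compound 2 and S in compound 3. Nothing leaves and nothing enters, since the two compounds have the same atoms and bonds, but a stereocentre at a saturated ring carbon is drawn R in compound 2 and S in compound 3.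

Within the data shown here, no measured pair shows what such a change does here. Among the measured compounds shown here, the only guide is the limit of > 100000 nM in this assay, at which 2 of the 2 values shown sit. On that basis, the step of a number no higher from compound 2 to compound 3 (the limit leaves the size open) is expected to be no larger than the scatter, with compound 3 most likely staying at the limit.

For compound 3, the estimated value is 100000 nM, with an expected range from 25000 nM to 200000 nM.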

Compound 3, half-maximal inhibitory concentration: > 100000 nM
Compound 3 ended at the assay's limit; the forecaster's own chance of this, stated with the estimate: 75%; the middle value lies on the limit itself.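

In this assay compound 3 gives > 100000 nM, which is a limit of the assay and not a number. The steps from compound 2 and from compound 1 to compound 3 cannot be read. The compounds shown leave open how strongly each one inhibits, and whether the configuration at that saturated ring carbon matters at all.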